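A few compounds are considered here, and "the series" means these few. Any claim that something is new, unique, unknown or untested is made for them only; others in the source may bear on it.

Working notes on the series. In a functional assay on DU-145 cells (Homo sapiens) for inhibition, read by trypan blue exclusion, with a stated time of 72 h (on this read-out higher numbers stand for weaker inhibition and lower numbers for stronger inhibition), compound 1 (`Cn1c(=O)c(S(=O)(=O)c2ccc(F)cc2F)cc2cnc(Nc3ccc4[nH]c(C(=O)O)cc4c3)nc21`) gives 10000 nM, compound 2 (`Cn1c(=O)c(S(=O)(=O)c2ccc(C(=O)O)cc2)cc2cnc(Nc3ccc4[nH]ccc4c3)nc21`) gives 10000 nM, and compound 3 (`Cn1c(=O)c(C(=O)Nc2ccc(F)cc2F)cc2cnc(Nc3ccc4[nH]ccc4c3)nc21`) gives 5000 nM. Compound 3 therefore lies within the usual scatter of both other compounds, and the three numbers support no ranking. No two of these compounds differ in only one place, so the effect of a single change in this series has not been measured.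

The next compound to be tested is compound 4 (`Cn1c(=O)c(S(=O)(=O)Cc2ccc(F)cc2)cc2cnc(Nc3ccc4[nH]ccc4c3)nc21`). Relative to compound 3, it has (4-fluorobenzyl)sulfonyl in place of (2,4-difluorophenyl)carbamoyl on an aromatic carbon. The rest of the structure is unchanged, including the neighbouring carbonyl and the methyl group.

Among the compounds with values here, with no measured step to draw on, the expectation rests on compound 3 at 5000 nM and on the narrow spread of the three values. No step beyond the scatter is expected in this assay, and any shift in direction is only a weak lean towards a lower number. The expected change is a 1.3-fold lower number from compound 3 to compound 4 (0.10 log units; within the scatter), and this estimate carries wide uncertainty. For compound 4 the estimated value is 4000 nM, with an expected range from 1000 nM to 10000 nM.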

Compound 4, half-maximal inhibitory concentration: 30000 nM
Compound 4: the middle estimate sits 7.5-fold (0.88 log units) below what was measured, and the stated range ends below it.
By their numbers in this assay, from the lowest: compounds 3, 1 and 2 (each within the scatter of the next); then compound 4.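

In this assay, the aromatic carbon carrying the (2,4-difluorophenyl)carbamoyl group now has a measured single-place change: (4-fluorobenzyl)sulfonyl in its stead gives a step (a 6.0-fold higher number from compound 3 to compound 4 (0.78 log units; beyond the scatter)), so this position can move the number, which the three earlier values, all within the scatter, could not show. The group on the sulfonyl sulfur also matters: with the sulfonyl kept, 4-fluorobenzyl in place of 4-carboxyphenyl gives a second step (a 3.0-fold higher number from compound 2 to compound 4 (0.48 log units; beyond the scatter)), and both changes run towards a higher number, meaning weaker inhibition. Nothing available on these compounds accounts for either step.

Still open, going by these compounds, is which part of the entering group carries the first step, as the linking carbamoyl and the ring substitution change together; a (4-fluorobenzyl)carbamoyl group at the same position would separate the two. Also open, on these data alone, is whether an amine or a longer alkyl chain on the sulfonyl sulfur would bring the number back down, or whether a carboxylic acid on the benzyl ring would shift it.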